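Benzothiophene replaces difluorophenyl on the sulfonamide nitrogen

The source may hold more compounds than are shown below. What is called first, only, known or untested is meant among the compounds shown, and "the series" means these compounds.

Compound 3 `CC(C)CN(c1ccc(F)cc1F)S(=O)(=O)c1ccc2c(c1)C(O)CC(C1CCOCC1)O2` stands highest of the three measured compounds in a physicochemical assay for lipophilicity, at pH 7.4 (on this read-out higher numbers stand for higher lipophilicity and lower numbers for lower lipophilicity), with 3.53. Its nearest neighbour is compound 1 `CC(C)CN(c1ccc(F)cc1)S(=O)(=O)c1ccc2c(c1)C(O)CC(C1CCOCC1)O2`, which in this assay gives 3.39; here a number 0.14 log units higher from compound 1 to compound 3 (within the scatter). Furthest away is compound 2 `CC(C)CN(c1ccc(C#N)cc1)S(=O)(=O)c1ccc2c(c1)C(O)CC(C1CCOCC1)O2`, which in this assay gives 3.07, so that a number 0.46 log units higher from compound 2 to compound 3 (beyond the scatter). Between the first two, a number 0.32 log units lower from compound 1 to compound 2 (beyond the scatter).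

Compound 4 `CC(C)CN(c1cc2ccccc2s1)S(=O)(=O)c1ccc2c(c1)C(O)CC(C1CCOCC1)O2` differs from compound 3 in one place: 1-benzothiophen-2-yl in place of 2,4-difluorophenyl on a sulfonamide nitrogen. Going by the values given here, none of the measured steps exchanges the whole aryl group on the sulfonamide nitrogen for a different ring system; the three steps among compounds 1, 2 and 3 only alter the substituents on a phenyl ring, and even so they moved this assay by modest amounts. The present change is larger than any of them, and a rise beyond the scatter is expected. Compound 4 is therefore estimated to give about 4.1 in this assay, expected to lie between 3.7 and 4.5. That estimate corresponds to an expected step of a number 0.57 log units higher from compound 3 to compound 4 (beyond the scatter).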

Compound 4, distribution coefficient: 3.92
Estimate against measurement, compound 4: 0.18 log units above; measured number inside the range.
By their numbers in this assay, from the lowest: compound 2; then compounds 1 and 3 (each within the scatter of the next); then compound 4.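

With the whole aryl group on the sulfonamide nitrogen exchanged, rather than only the substituents on a phenyl ring, this assay shows a number 0.39 log units higher from compound 3 to compound 4 (beyond the scatter) and a number 0.53 log units higher from compound 1 to compound 4 (beyond the scatter) and a number 0.85 log units higher from compound 2 to compound 4 (beyond the scatter) for this change. Compound 4 therefore stands alone at the top of the series, and the step holds against 2,4-difluorophenyl, 4-fluorophenyl and 4-cyanophenyl alike. Nothing available explains why the number moves.

The compounds shown leave open which part of 1-benzothiophen-2-yl carries the step, the five-membered aromatic ring with its sulfur or the fused six-membered ring; a thiophen-2-yl or a naphthalen-2-yl group on the same nitrogen would separate the two. Also open, from the compounds shown here alone, is how the read-out would respond to an amine or a carboxylic acid on the entering ring.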